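Methoxy to hydroxy in the thioether series

This account rests on a few compounds, and the source may have more. Where it says the series, first, only, none or still open, it means among the compounds named here.

Measured in a functional assay on MCF7 cells (Homo sapiens) for inhibition, with a stated time of 48 h; a lower number here means a stronger inhibitor, a higher number a weaker inhibitor:
compound 1 `COc1cc(Sc2c[nH]c3ccccc23)cc(OC)c1OC` gives 34 nM
compound 2 `COc1ccc2[nH]cc(Sc3cc(OC)c(OC)c(OC)c3)c2c1` gives 22 nM

Within the data shown here, compound 2 and compound 1 are the only two measured compounds, and their values lie within the scatter of each other. Compound 3 `COc1cc(Sc2c[nH]c3ccc(O)cc23)cc(OC)c1OC` differs from compound 2 by hydrogen in place of methyl on an oxygen on an aromatic ring (hydrogen in place of methyl on an oxygen on an aromatic ring, or methoxy to hydroxy). Among the measured compounds shown here, the one measured step that bears on this is the methoxy in place of hydrogen, a 1.5-fold lower number from compound 1 to compound 2 (0.19 log units; within the scatter) (within the scatter). For the measured compounds named here, no hydroxy compound has been measured yet. No step beyond the scatter is therefore expected in this assay for this change. The estimate means a 1.6-fold higher number from compound 2 to compound 3 (0.20 log units; within the scatter) (an expected step inside the scatter). For compound 3 the expected value is 35 nM (estimated range 10 nM to 120 nM).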

Compound 3, half-maximal inhibitory concentration: 190 nM
Compound 3: middle estimate off by 5.4-fold (0.73 log units), on the low side; measured number above the stated range.
By their numbers in this assay, from the lowest: compounds 2 and 1 (each within the scatter of the next); then compound 3.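

The position is not indifferent to what it carries. In this assay, methoxy and hydrogen stay within the scatter of each other, while hydroxy separates from both (an 8.6-fold higher number from compound 2 to compound 3 (0.94 log units; beyond the scatter); a 5.6-fold higher number from compound 1 to compound 3 (0.75 log units; beyond the scatter)). Nothing at hand accounts for this separation.

Open, on these data alone, is whether an ethoxy group, an amine or a fluorine at this place would stay with methoxy and hydrogen or fall with hydroxy. Also open, as far as these compounds go, is whether the same change from methoxy to hydroxy elsewhere on the shared core would cost as much.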